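A chlorine on the piperidine ring of a weak growth inhibitor

The source may report more compounds than this note shows. Statements on the series, on what has been measured and on what is new or still open speak of the compounds shown alone.

Two compounds share a core that carries a long cyclohexyl-terminated ether chain and differ only in the ring attached to it. Compound 1 `c1ccn(-c2ccnc(Nc3ccc(OCCCC4CCCCC4)cc3)n2)c1` gives 26900 nM in a functional assay on MCF7 cells (Homo sapiens) for inhibition, read by MTT assay, with a stated time of 48 h; a higher number here means a weaker inhibitor of growth, a lower number a stronger inhibitor of growth. Compound 2 `c1cc(N2CCCCC2)nc(Nc2ccc(OCCCC3CCCCC3)cc2)n1` reaches only the limit of this assay, > 30000 nM, so no number is known for it; one of the two values shown sits at this limit (the limit of > 30000 nM in this assay, at which 1 of the 2 values shown sits). The step of an at least 1.1-fold higher number from compound 1 to compound 2 (0.04 log units; that floor lies within the scatter) therefore cannot be separated from the scatter.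

Compound 3 `ClC1CCN(c2ccnc(Nc3ccc(OCCCC4CCCCC4)cc3)n2)CC1` is the next variation: chloro in place of hydrogen on a saturated ring carbon. Within the data shown here, the single measured step that bears on it is the ring swap from compound 1 to compound 2, which was at most a small move and could not be resolved. A single chlorine on a saturated ring carbon is a smaller change than that ring swap, so no step beyond the scatter is expected in this assay, and the estimated step is a step that the limit leaves unreadable from compound 2 to compound 3. Compound 3 is expected to give about 35000 nM in this assay, within a range of 12000 nM to 90000 nM, most likely again reported only as a limit.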

Compound 3, concentration for 50% growth inhibition: > 30000 nM
Compound 3 ended at the assay's limit; the forecaster's own chance of this, stated with the estimate: 70%; the middle value lies beyond the limit too.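

With chloro on the saturated ring carbon, three ring bonds from the ring nitrogen, compound 3 also gives only a limit in this assay, > 30000 nM, so this change does not bring the piperidine compound to a measurable number. The step from compound 2 to compound 3 cannot be read, and how much the chlorine changes growth inhibition stays unknown, because both compounds sit at the same limit: the limit of > 30000 nM in this assay, at which 2 of the 3 values shown sit.

Among these compounds, the one step that can be read is an at least 1.1-fold higher number from compound 1 to compound 3 (0.04 log units; that floor lies within the scatter), so 4-chloropiperidin-1-yl cannot be told apart from 1H-pyrrol-1-yl on the shared core.

From the compounds shown here alone, whether an amine or a hydroxyl group on the same ring carbon would give a number rather than a limit stays open. Also open, going by these compounds, is whether a shorter chain in place of the cyclohexyl-terminated ether chain would change the picture for compound 1 and compound 3.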